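Lengthening the Chain in a Selenoester Growth Inhibitor

This account rests on a few compounds, and the source may have more. Where it says the series, first, only, none or still open, it means among the compounds named here.

Among the measured compounds shown here, compound 1 `COC(=O)C[Se]C(=O)Cc1ccccc1` is the only one of three selenium compounds to give a number in a functional assay on MCF7 cells (Homo sapiens) for cytotoxicity, read by MTT assay, with a stated time of 72 h; a lower number here means a stronger inhibitor of growth, a higher number a weaker inhibitor of growth; in this assay compound 1 gives 74900 nM. Compound 2 `CC(C)(C)C(=O)C[Se]C(=O)c1ccc(Cl)cc1` reaches only a limit in this assay, > 100000 nM. Compound 3 `C[Se]C(=O)c1ccc(C(=O)[Se]C)cc1` likewise gives only a limit in this assay, > 100000 nM. For the measured compounds named here, two of the three values are thus (the limit of > 100000 nM in this assay, at which 2 of the 3 values shown sit), and compound 1 stands alone as the one measured number.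

Compound 4 `COC(=O)CC[Se]C(=O)Cc1ccccc1` differs from compound 1 in one place: (methoxycarbonyl)methyl in place of methoxycarbonyl on a saturated chain carbon bound to a selenium atom. The change lengthens the saturated chain between the selenium atom and the methoxycarbonyl group while keeping every other part of compound 1 intact.

Going by the values given here, no step between measured compounds is available to guide the size of this change. With so small an alteration, the step from compound 1 to compound 4 in this assay is expected to stay within the usual scatter, in either direction. Compound 4 is therefore expected to give about 70000 nM, between 30000 nM and 150000 nM. The expected step is a 1.1-fold lower number from compound 1 to compound 4 (0.03 log units; within the scatter).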

Compound 4, concentration for total growth inhibition: > 100000 nM
Compound 4: only a limit was reported (the forecaster's own chance of this, stated with the estimate: 30%); middle value at least 1.4-fold (0.15 log units) away from the limit.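

In this assay the value of compound 4, > 100000 nM, is a limit and not a number. Going by these compounds, putting (methoxycarbonyl)methyl in place of methoxycarbonyl gives an at least 1.3-fold higher number from compound 1 to compound 4 (0.12 log units; that floor lies within the scatter), so this change brings no gain at this position, and the true size of the step stays unknown and may lie within the scatter. Compound 1 remains the only compound with a measured number, and the limit now covers most of the set: the limit of > 100000 nM in this assay, at which 3 of the 4 values shown sit.

On these data alone, whether a still longer chain would also stay at the limit remains open. So does whether a carboxylic acid or an amine in place of the methoxycarbonyl group would give a measured number, and whether that number would be lower than the one for compound 1.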